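The source may hold more compounds than are shown below. What is called first, only, known or untested is meant among the compounds shown, and "the series" means these compounds.

Compound 1 `C[C@@H](c1nnc(-c2ccc(Cl)cc2)o1)[C@H]1CC[C@@H](c2ccnc3ccc(F)cc32)CC1`: 41%
Compound 2 `CCC(Nc1nnc(-c2ccc(OC)cc2)o1)[C@H]1CC[C@@H](c2ccnc3c(F)cc(F)cc32)CC1`: 8%

In an ADME assay on microsomes from liver (Mus musculus) for metabolic stability, with a stated time of 10 min, tested at 0.5 uM (a higher number here means that more of the compound is left, a lower number that less of the compound is left), compound 1 gives 41%. Compound 2 stands lowest of the two numbers; in this assay compound 2 gives 8%, a gap beyond the scatter, though these two compounds differ in more than one place.

Compound 3 `CCC(Nc1nnc(-c2ccc(OC)cc2)o1)[C@H]1CC[C@@H](c2ccnc3ccc(F)cc32)CC1` has not been measured yet. It differs from compound 2 by hydrogen in place of fluoro on an aromatic carbon, a small change that removes one heavy atom. Within the shared core little else moves, so the step in this assay is expected to be small, in either direction, and may fall within the scatter. Compound 3 is expected to give 10%, within a range of 3% to 25%, a step of a number 2 percentage points higher from compound 2 to compound 3 (within the scatter).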

Compound 3, percent of the compound remaining: 31%
Compound 3: the middle estimate sits 21 percentage points below what was measured; measured number outside the range, above it.
By their numbers in this assay, from the lowest: compound 2; then compounds 3 and 1 (each within the scatter of the next).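

Hydrogen in place of fluoro on this aromatic carbon, ortho to a fused ring, gives a number 23 percentage points higher from compound 2 to compound 3 (beyond the scatter) in this assay and is the first change here that can be read on its own. This single position therefore matters for how much compound is left, and exchanging one atom is enough to move the number beyond the scatter. Nothing available explains the step. From the compounds shown here alone, whether a methyl or a nitrile at this position would leave more or less of the compound remains open, as does whether the same exchange behaves alike in other compounds.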